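This account rests on a few compounds, and the source may have more. Where it says the series, first, only, none or still open, it means among the compounds named here.

Compound 1 `COc1c2ccccc2nn1C(C)C` sits at the low end of the three values gathered so far. In an assay on isolated protein (urine) for inhibition of Myeloperoxidase (Homo sapiens), read by spectrophotometry (on this read-out higher numbers stand for weaker inhibition and lower numbers for stronger inhibition), compound 1 gives 704 nM. Compound 3 `CCCCn1nc2ccccc2c1OCC`, which carries a butyl group on the ring nitrogen and an ethoxy group on the carbon, gives 807 nM in this assay, a value within the scatter of that of compound 1. Among the measured compounds shown here, compound 2 `COCCOc1c2ccccc2nn1C(C)C` gives 1400 nM, and the only single step measured, a 2.0-fold higher number from compound 1 to compound 2 (0.30 log units; within the scatter), concerns the alkoxy side rather than the substituent on the nitrogen.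

Compound 4 `CCCCCn1nc2ccccc2c1OC` differs from compound 1 by pentyl in place of isopropyl on an aromatic nitrogen. For the measured compounds named here, no measured step addresses this change directly. The closest hint comes from compound 3: its butyl group on the aromatic nitrogen, together with an ethoxy group, left the value within the scatter of compound 1. On that basis a lengthening of the chain on the nitrogen from isopropyl to pentyl is expected to give at most a small shift, with no clear direction beyond the scatter. The step from compound 1 to compound 4 is estimated as a 1.2-fold lower number from compound 1 to compound 4 (0.07 log units; within the scatter). For compound 4 the expected value in this assay is 600 nM, with a range from 250 nM to 1500 nM.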

Compound 4, half-maximal inhibitory concentration: 3880 nM
Compound 4: the middle estimate sits 6.5-fold (0.81 log units) below what was measured; measured number above the stated range.
By their numbers in this assay, from the lowest: compounds 1, 3 and 2 (each within the scatter of the next); then compound 4.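

Putting pentyl in place of isopropyl on the aromatic nitrogen gives, in this assay, a 5.5-fold higher number from compound 1 to compound 4 (0.74 log units; beyond the scatter) and this is the first single step shown that lies beyond the scatter. Among the compounds shown here, the alkoxy side had so far given only a 2.0-fold higher number from compound 1 to compound 2 (0.30 log units; within the scatter) and that step stays within the scatter, so the substituent on the aromatic nitrogen is the place where a single change has been seen to weaken inhibition. Nothing available explains why this swap of one alkyl group for another has this effect.

The compounds shown leave open whether the loss lies in the length of the chain or in the removal of isopropyl itself, since compound 3 at 807 nM carries butyl but also differs from compound 1 in its ethoxy group, and so gives no single step on this question. A propyl or butyl group on the nitrogen with the methoxy group kept, or a pentyl chain ending in an amine or a carboxylic acid, would bear on how the values run at this position.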